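Removing Two Chlorines from a Formyl-Bearing Core

The compounds below may be only part of what the source reports. "The series", "measured", "known", "first", "only" and "open" are said of these compounds alone.

Measured compounds:
compound 1 `Clc1ccc(Cc2nn3cc(-c4ccc(Cl)cc4Cl)nc3s2)cc1`: 247000 nM
compound 2 `Clc1ccc(Cc2nn3cc(-c4ccccc4)nc3s2)cc1`: > 250000 nM, a limit of the assay
compound 3 `O=Cc1c(-c2ccc(Cl)cc2Cl)nc2sc(Cc3ccc(Cl)cc3)nn12`: 82000 nM

All three were tested in a functional assay on L1210 cells (Mus musculus) for cytotoxicity, with a stated time of 48 h; a lower number here means a stronger inhibitor, a higher number a weaker inhibitor. The change from compound 1 to compound 2 is phenyl in place of 2,4-dichlorophenyl on an aromatic carbon; it gave an at least 1.0-fold higher number from compound 1 to compound 2 (0.00 log units; that floor lies within the scatter), and compound 2 sits at the limit of > 250000 nM in this assay, at which 1 of the 3 values shown sits. Compound 3 differs from compound 1 by formyl in place of hydrogen on an aromatic carbon, giving a 3.0-fold lower number from compound 1 to compound 3 (0.48 log units; beyond the scatter). Compound 4 `O=Cc1c(-c2ccccc2)nc2sc(Cc3ccc(Cl)cc3)nn12` is not yet measured. It differs from compound 3 by phenyl in place of 2,4-dichlorophenyl on an aromatic carbon, the same kind of change as that from compound 1 to compound 2, though here the ring carbon is also next to the ring atom that bears a formyl group. Since the earlier change gave an at least 1.0-fold higher number from compound 1 to compound 2 (0.00 log units; that floor lies within the scatter), compound 4 is expected to show a 2.4-fold higher number from compound 3 to compound 4 (0.39 log units; beyond the scatter). Compound 4 is estimated at 200000 nM, between 70000 nM and 500000 nM.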

Compound 4, half-maximal inhibitory concentration: 20000 nM
Compound 4: the middle estimate sits 10-fold (1.00 log units) above what was measured; measured number below the stated range.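

In this assay, phenyl in place of 2,4-dichlorophenyl on the formyl-bearing core gave a 4.1-fold lower number from compound 3 to compound 4 (0.61 log units; beyond the scatter), so this change did not carry over unchanged from the core without formyl: the same change on two cores in this assay, an at least 1.0-fold higher number (0.00 log units; that floor lies within the scatter) from compound 1 to compound 2 and a 4.1-fold lower number (0.61 log units; beyond the scatter) from compound 3 to compound 4, at least 4.1-fold (0.61 log units) apart, beyond the scatter of two such steps
Likewise, formyl in place of hydrogen gave an at least 12-fold lower number from compound 2 to compound 4 (1.09 log units; beyond the scatter) on the phenyl-bearing core, and the size of this step depended on the core: the same change on two cores in this assay, a 3.0-fold lower number (0.48 log units; beyond the scatter) from compound 1 to compound 3 and an at least 12-fold lower number (1.09 log units; beyond the scatter) from compound 2 to compound 4, at least 4.1-fold (0.61 log units) apart, beyond the scatter of two such steps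
Compound 2 gives > 250000 nM, which is a limit of the assay, and these four compounds do not show why the steps differ or whether the same holds on any other core.

Going by these compounds, it remains open how a carboxylic acid or an amine in place of the formyl would behave. Whether either would keep the gain seen with formyl cannot be told from these compounds.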